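Amine swap on the propoxy chain: compound 2 to compound 3

This account rests on a few compounds, and the source may have more. Where it says the series, first, only, none or still open, it means among the compounds named here.

Within the data shown here, compound 1 `COc1cc2c(Oc3ccc(NC(=O)c4nn(-c5cccc(F)c5)c(=O)cc4C)cc3F)ccnc2cc1OCCCN1CCN(C)CC1` and compound 2 `COc1cc2c(Oc3ccc(NC(=O)c4nn(-c5ccc(F)c(F)c5)c(=O)cc4C)cc3F)ccnc2cc1OCCCN1CCCC1` share the same core and differ in two places at once, so no single step between them is counted. In a functional assay on NCI-H460 cells (Homo sapiens) for inhibition, read by MTT assay, with a stated time of 72 h (on this read-out lower numbers stand for stronger inhibition and higher numbers for weaker inhibition), compound 1 gives 260 nM. In this assay compound 2 gives 170 nM, the smallest of the two numbers on hand; the nearest number, that of compound 1, sits within the usual scatter, so the two are not distinguishable.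

Compound 3 `COc1cc2c(Oc3ccc(NC(=O)c4nn(-c5ccc(F)c(F)c5)c(=O)cc4C)cc3F)ccnc2cc1OCCCN1CCN(C)CC1` differs from compound 2 in one place: 4-methylpiperazin-1-yl in place of pyrrolidin-1-yl on a saturated chain carbon, three bonds along the chain from an oxygen on an aromatic ring. Among the measured compounds shown here, no measured pair shows this change alone, so its size is unknown; the only guide is compound 1, which carries the same amine and gives 260 nM. The expected step of a 1.3-fold higher number from compound 2 to compound 3 (0.11 log units; within the scatter) is therefore taken as none beyond the scatter. Compound 3 is expected to give 220 nM, within a range from 110 nM to 450 nM.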

Compound 3, half-maximal inhibitory concentration: 190 nM
Compound 3: middle estimate off by 1.2-fold (0.06 log units), on the high side; the range from low to high includes it.
By their numbers in this assay, from the lowest: compounds 2, 3 and 1 (each within the scatter of the next).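

Working notes: in this assay the position on the saturated chain carbon, three bonds along the chain from an oxygen on an aromatic ring, now has a read single step: 4-methylpiperazin-1-yl in place of pyrrolidin-1-yl gives a 1.1-fold higher number from compound 2 to compound 3 (0.05 log units; within the scatter) and so shows no difference between these two amines on this core. Fluoro in place of hydrogen on an aromatic carbon, previously tangled with the amine change, can now be read alone (a 1.4-fold lower number from compound 1 to compound 3 (0.14 log units; within the scatter)) and also shows no difference, so neither of the two changes separating compound 1 and compound 2 stands out. Nothing on hand bears on why either step is this small.

The compounds shown leave open whether morpholin-4-yl, a dimethylamino group or a carboxylic acid at this chain end would also stay within the scatter. Also open, going by these compounds, is whether a shorter ethyl or a longer butyl chain would carry the amine equally well.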